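The source may report more compounds than this note shows. Statements on the series, on what has been measured and on what is new or still open speak of the compounds shown alone.

Compound 2 `O=C(CSc1nc(Nc2ccccc2)c2ccccc2n1)Nc1cccc(Cl)c1` gives the lowest number of the three in a functional assay on NCI-H1975 cells (Homo sapiens) for inhibition, read by MTT assay, with a stated time of 72 h (on this read-out higher numbers stand for weaker inhibition and lower numbers for stronger inhibition), at 8460 nM, though its neighbours sit within the scatter: compound 1 `O=C(CSc1nc(Nc2ccccc2)c2ccccc2n1)Nc1ccccc1Cl` gives 9610 nM and compound 3 `O=C(CSc1nc(Nc2ccccc2)c2ccccc2n1)Nc1ccc(F)cc1` gives 16500 nM. Compound 4 `O=C(CSc1nc(Nc2ccccc2)c2ccccc2n1)Nc1ccc(Br)cc1` has not yet been measured; the change is 4-bromophenyl in place of 3-chlorophenyl on an amide-type nitrogen. Within the data shown here, the steps that bear on it are small: a 1.1-fold lower number from compound 1 to compound 2 (0.06 log units; within the scatter), a 1.7-fold higher number from compound 1 to compound 3 (0.23 log units; within the scatter) and a 2.0-fold higher number from compound 2 to compound 3 (0.29 log units; within the scatter). Since the 4-fluorophenyl step from compound 2 to compound 3 stayed within the scatter, the step to compound 4 is expected to be a 1.4-fold higher number from compound 2 to compound 4 (0.15 log units; within the scatter), with no clear direction beyond the scatter. Compound 4 is therefore estimated at 12000 nM, within a range of 5000 nM to 30000 nM.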

Compound 4, half-maximal inhibitory concentration: 10600 nM
Compound 4: middle estimate off by 1.1-fold (0.05 log units), on the high side; measured number inside the range.
By their numbers in this assay, from the lowest: compounds 2, 1, 4 and 3 (each within the scatter of the next).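

With 4-bromophenyl on the amide-type nitrogen, this assay still shows no separation from any earlier compound (a 1.3-fold higher number from compound 2 to compound 4 (0.10 log units; within the scatter)) (a 1.1-fold higher number from compound 1 to compound 4 (0.04 log units; within the scatter)). Among these compounds, the direct exchange of bromo for fluoro on an aromatic carbon adds the first comparison of these two halogens and also stays within the scatter (a 1.6-fold lower number from compound 3 to compound 4 (0.19 log units; within the scatter)). No measurement offered here explains these results.

All four groups at this position are halogen-bearing phenyl rings. As far as these compounds go, whether an amine, a carboxylic acid or a methoxy group on that ring would move the number beyond the scatter remains open.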